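Solubility notes: aminopropyl sulfone in place of piperazinyl sulfonamide

This account rests on a few compounds, and the source may have more. Where it says the series, first, only, none or still open, it means among the compounds named here.

Two compounds of the shared core have numbers in a physicochemical assay for solubility, at pH 6.5; on this read-out higher numbers stand for higher solubility and lower numbers for lower solubility. Compound 1 `CS(=O)(=O)c1cccc(-c2ccc3ncc(-c4ccc(S(=O)(=O)N5CCNCC5)cc4)n3n2)c1` gives 162000 nM in this assay, the lower of the two numbers, while compound 2 `O=S(=O)(c1cccc(-c2ccc3ncc(-c4ccc(-c5nnn[nH]5)cc4)n3n2)c1)C1CC1` gives 183000 nM; the two lie within the scatter of each other, so their gap carries no reading of order. Compound 3 `CS(=O)(=O)c1cccc(-c2ccc3ncc(-c4ccc(S(=O)(=O)CCCN)cc4)n3n2)c1` is not yet measured in this assay. It differs from compound 1 by 3-aminopropyl in place of piperazin-1-yl on a sulfonyl sulfur. Among the compounds with values here, no measured pair shows this change, so no step size for it is known from data. The expectation is a step of no size beyond the scatter, in either direction, as a 1.1-fold higher number from compound 1 to compound 3 (0.05 log units; within the scatter). Compound 3 is accordingly estimated at 180000 nM in this assay, with a range of 90000 nM to 360000 nM.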

Compound 3, solubility: 180000 nM
Estimate against measurement, compound 3: no gap at the digits printed; low and high end bracket the measured number.
By their numbers in this assay, from the lowest: compounds 1, 3 and 2 (each within the scatter of the next).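

In this assay, within the data shown here, the only measured step at this position is a 1.1-fold higher number from compound 1 to compound 3 (0.05 log units; within the scatter) for 3-aminopropyl in place of piperazin-1-yl on a sulfonyl sulfur whose other neighbour is an aromatic carbon. The read-out therefore does not separate the six-membered non-aromatic ring from the open chain, with 4 heavy atoms entering where 6 leave and the counts of hydrogen-bond donors and acceptors unchanged. No measured information on these compounds accounts for this outcome.

Going by these compounds, a carboxylic acid, a morpholine or a longer chain bearing an amine on the same sulfonyl sulfur remains open. This single pair also leaves open how the same change reads with a group other than the methyl sulfone of compound 1 on the shared core.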